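A Phenyl Gives Way to 2-Hydroxyethyl

This account rests on a few compounds, and the source may have more. Where it says the series, first, only, none or still open, it means among the compounds named here.

Measured in an ADME assay on C2C12 cells (Mus musculus) for cytotoxicity; a lower number here means that less compound is tolerated, a higher number that more compound is tolerated:
- Compound 1 `c1ccc(CNc2nc(Nc3ccccn3)nc3ccccc23)cc1`: > 10000 nM (a limit of the assay, not a number)
- Compound 2 `Clc1ccc(Nc2nc(NCc3ccccc3)c3ccccc3n2)cc1`: 10000 nM

Among the compounds with values here, compound 2, at 10000 nM, holds the only actual number in this assay so far. Compound 1 stands at the limit of > 10000 nM in this assay, at which 1 of the 2 values shown sits, which is a limit.

The next compound to be measured is compound 3 `OCCCNc1nc(Nc2ccc(Cl)cc2)nc2ccccc12`. Its structure departs from that of compound 2 in one place: 2-hydroxyethyl in place of phenyl on a saturated chain carbon bound to a nitrogen on an aromatic ring. Read one bond further out, benzylamino becomes (3-hydroxypropyl)amino.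

Within the data shown here, only one measured step exists, a number no higher from compound 1 to compound 2 (the limit leaves the size open). The limit leaves its size open, and it exchanges a different group, so it gives no direct guide to the loss of this phenyl. The expectation therefore rests mainly on compound 2 at 10000 nM. Among the measured compounds shown here, with no measured step to suggest a direction, no change beyond the scatter is expected in this assay: no change at the digits printed from compound 2 to compound 3 (within the scatter). The assay may well report only a limit again. For compound 3 the estimated value is 10000 nM, with an expected range from 4000 nM to 25000 nM.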

Compound 3, half-maximal cytotoxic concentration: > 10000 nM
Compound 3: no number, only a limit; the forecaster's own chance of this, stated with the estimate: 60%; the middle value lies on the limit itself.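

At this position, on a saturated chain carbon bound to a nitrogen on an aromatic ring, exchanging phenyl for 2-hydroxyethyl in this assay gives a number no lower from compound 2 to compound 3 (the limit leaves the size open). Within the data shown here, this is the first view of this position, since the earlier step changed only the group on the other nitrogen, and it shows that the cell line tolerates the loss of the six-membered aromatic ring without the reading falling: benzylamino can give way to (3-hydroxypropyl)amino, with its added hydrogen-bond donor and acceptor, and the number does not drop. What the result cannot do is rank the compounds, and most of them now sit at the same boundary of the assay: the limit of > 10000 nM in this assay, at which 2 of the 3 values shown sit.

The compounds shown leave open how far compound 3 lies from compound 2, and whether any real difference separates them at all. They also leave open whether an amine, a carboxylic acid or a longer chain in place of the 2-hydroxyethyl would keep the reading at this limit or bring a measurable number in this assay.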